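Turning the Thiophene Ring Around on a Shared Core

This account rests on a few compounds, and the source may have more. Where it says the series, first, only, none or still open, it means among the compounds named here.

Compound 1, `O=c1[nH]cnc2c1c(-c1ccoc1)cn2[C@@H]1O[C@H](CO)[C@@H](O)[C@H]1O`, gives 12100 nM in a functional assay on HepG2 cells (Homo sapiens) for antiproliferative activity, read by XTT assay, with a stated time of 72 h; on this read-out lower numbers stand for stronger inhibition and higher numbers for weaker inhibition.
Compound 2, `C#Cc1cn([C@@H]2O[C@H](CO)[C@@H](O)[C@H]2O)c2ncnc(C)c12`, gives 290 nM.
Compound 3, `O=c1[nH]cnc2c1c(-c1cccs1)cn2[C@@H]1O[C@H](CO)[C@@H](O)[C@H]1O`, reaches only a limit of the assay, > 20000 nM.

Compound 3 therefore stands at the limit of > 20000 nM in this assay, at which 1 of the 3 values shown sits, with no number of its own; compound 1, its furan-3-yl counterpart, does have a number. Among the compounds with values here, the one measured step that touches this part of the molecule is an at least 1.6-fold higher number from compound 1 to compound 3 (0.21 log units; that floor lies within the scatter), and it does not exceed the scatter.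

Compound 4, `O=c1[nH]cnc2c1c(-c1ccsc1)cn2[C@@H]1O[C@H](CO)[C@@H](O)[C@H]1O`, differs from compound 3 by thiophen-3-yl in place of thiophen-2-yl on an aromatic carbon. Within the data shown here, no measured step swaps the attachment point of a ring this way, so the expected step is an at least 1.3-fold lower number from compound 3 to compound 4 (0.12 log units; that floor lies within the scatter), small and likely within the scatter. Compound 4 is accordingly expected to give about 15000 nM, within a range from 5000 nM to 40000 nM, with a fair chance that only a limit is reported.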

Compound 4, half-maximal inhibitory concentration: > 15000 nM
Compound 4: no number, only a limit; the forecaster's own chance of this, stated with the estimate: 45%; the middle value lies on the limit itself.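

In this assay compound 4 also reaches only a limit, so moving the attachment point of the thiophene ring yields no measured number at this position: the limit of > 15000 nM in this assay, at which 1 of the 4 values shown sits.

The step from compound 3 to compound 4 cannot be read, since both values are limits. Set against the furan-3-yl group, thiophen-3-yl gives an at least 1.2-fold higher number from compound 1 to compound 4 (0.09 log units; that floor lies within the scatter), so this swap, like the thiophen-2-yl one, is not shown to exceed the scatter.

Going by these compounds, how far compound 3 and compound 4 lie beyond their limits remains open. So does whether an aminomethyl group or a carboxylic acid at this place on the shared core would give a lower number than the furan-3-yl group.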